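The source may report more compounds than this note shows. Statements on the series, on what has been measured and on what is new or still open speak of the compounds shown alone.

Measured in an ADME assay for permeability, using PAMPA, at pH 7.4; on this read-out higher numbers stand for higher permeability and lower numbers for lower permeability:
compound 1, `Cc1cc(NC(=O)Nc2ccccc2C(F)(F)F)c2ccccc2n1`: 945 10^-6 cm/s
compound 2, `Cc1ccc(NC(=O)Nc2cc(C)nc3ccccc23)cc1`: 669 10^-6 cm/s
compound 3, `CSc1ccccc1NC(=O)Nc1cc(C)nc2ccccc12`: 1260 10^-6 cm/s

Compound 3 has the highest of the three numbers, yet its distance to compound 1 and to compound 2 stays within the usual scatter, so the three compounds cannot be ordered. Compound 4, `Cc1cc(NC(=O)Nc2ccccc2N)c2ccccc2n1`, differs from compound 3 in a single place: amino in place of methylsulfanyl on an aromatic carbon. Within the data shown here, the only measured step at that place, a 1.3-fold higher number from compound 1 to compound 3 (0.12 log units; within the scatter), stayed within the scatter. Among the measured compounds shown here, none of the measured steps adds a hydrogen-bond donor, so the data offer no direct guide. The step to compound 4 is therefore expected to be a 2.1-fold lower number from compound 3 to compound 4 (0.32 log units; beyond the scatter), a modest drop with wide uncertainty. Compound 4 is estimated at 600 10^-6 cm/s, between 300 10^-6 cm/s and 1200 10^-6 cm/s.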

Compound 4, apparent permeability: 300 10^-6 cm/s
Beside the measured number, compound 4's estimate is 2.0-fold (0.30 log units) above it, and the stated range covers the measured number.
By their numbers in this assay, from the lowest: compound 4; then compounds 2, 1 and 3 (each within the scatter of the next).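

Among these compounds, at this aromatic carbon, amino is the first group to move the number in this assay beyond the scatter (a 4.2-fold lower number from compound 3 to compound 4 (0.62 log units; beyond the scatter)) and (a 3.2-fold lower number from compound 1 to compound 4 (0.50 log units; beyond the scatter)), whereas the exchange of trifluoromethyl for methylsulfanyl stayed within it (a 1.3-fold higher number from compound 1 to compound 3 (0.12 log units; within the scatter)). The change of 4-methylphenyl to 2-aminophenyl on the amide-type nitrogen also goes beyond the scatter (a 2.2-fold lower number from compound 2 to compound 4 (0.35 log units; beyond the scatter)), which leaves compound 4 alone at the low end of the set. Nothing measured here accounts for these drops. On these data alone, what a hydroxyl or a dimethylamino group would give at this place stays open.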